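Amide substituent exchange on the core of compound 2

This account rests on a few compounds, and the source may have more. Where it says the series, first, only, none or still open, it means among the compounds named here.

Compound 1 `CCn1c(C(=O)NCCN)ccc1C(CC)(CC)c1ccc(OCC(=O)C(C)(C)C)c(C)c1` and compound 2 `CCN(CC)CCCNC(=O)c1ccc(C(CC)(CC)c2ccc(OCC(O)C(C)(C)C)c(C)c2)n1CC` share a core but differ from each other in more than one place, so only their two numbers are set side by side. In an assay on isolated protein for binding affinity to vitamin D3 receptor (Homo sapiens), with a stated time of 4 h (a lower number here means a stronger inhibitor, a higher number a weaker inhibitor), compound 1 gives 1010 nM. In this assay, going by the values given here, compound 2 gives 71.1 nM, the lowest of the two numbers measured so far; compound 1 is its nearest neighbour, and that gap is beyond the scatter.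

Compound 3 `CCn1c(C(=O)N(CCC#N)CCC#N)ccc1C(CC)(CC)c1ccc(OCC(O)C(C)(C)C)c(C)c1` keeps everything of compound 2 except the substituent on the amide: a group of 9 heavy atoms (6 carbon, 3 nitrogen; no ring) in place of a group of 9 heavy atoms (7 carbon, 2 nitrogen; no ring), on a carbonyl carbon. Among the compounds with values here, no measured pair differs in this one place alone, so the step has no direct precedent, and the two measured compounds give no guide to it. The working expectation is a modest step from compound 2 to compound 3 toward a higher number, a 2.5-fold higher number from compound 2 to compound 3 (0.40 log units; beyond the scatter), possibly no larger than the usual scatter. For compound 3 in this assay the estimate is 180 nM, with a range from 50 nM to 700 nM.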

Compound 3, half-maximal inhibitory concentration: > 10000 nM
Compound 3: no number, only a limit; the forecaster's own chance of this, stated with the estimate: 5%; at least 55-fold (1.74 log units) between middle value and limit.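

Compound 3 reads > 10000 nM in this assay, which is a limit of the assay and not a number: the limit of > 10000 nM in this assay, at which 1 of the 3 values shown sits.

Going by these compounds alone, the earlier pair differed in more than one place, so this is the first reading of the amide substituent alone, and it shows that the position is far from indifferent to exchange: on this carbonyl carbon, replacing (3-(diethylamino)propyl)amino gives an at least 140-fold higher number from compound 2 to compound 3 (2.14 log units; beyond the scatter). Both groups hold 9 heavy atoms and neither has a ring, so heavy-atom count alone does not separate them. The counted differences lie elsewhere: the entering group has 0 hydrogen-bond donors, 2 hydrogen-bond acceptors and 2 triple bonds, while the leaving group has 1 donor and 1 acceptor.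

The compounds shown do not separate the loss of the amide hydrogen from the arrival of the nitrile groups or the loss of the diethylamino end, and a single 2-cyanoethyl chain on the amide nitrogen would divide these changes. On these data alone, how far the chain end tolerates other groups also stays open, for instance a piperidine or a carboxylic acid in place of the diethylamino group.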